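Shortening the side chain of compound 1

The source may report more compounds than this note shows. Statements on the series, on what has been measured and on what is new or still open speak of the compounds shown alone.

Compound 1 `CN(C)C(=O)c1cc2cnc(Nc3ccc(S(=O)(=O)NCCCN=C=S)cc3)nc2n1C1CCCC1` gives the highest of the two numbers measured in a functional assay on A549 cells (Homo sapiens) for inhibition, read by CCK-8 assay, with a stated time of 72 h, tested at 10 uM (a higher number here means a stronger effect of the compound at the concentration tested, a lower number a weaker effect), with 102%. Its only measured companion, compound 2 `CN(C)C(=O)c1cc2cnc(Nc3ccc(C(=O)NCCCCN=C=S)cc3O)nc2n1C1CCCC1`, reaches 41.7% in this assay, a reading far enough below compound 1 to lie beyond the usual scatter; the two compounds differ in more than one place, so what separates them cannot be tied to a single change.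

Compound 3 `CN(C)C(=O)c1cc2cnc(Nc3ccc(N=C=S)cc3)nc2n1C1CCCC1` has not been measured. Relative to compound 1 it carries a group of 3 heavy atoms (1 carbon, 1 nitrogen, 1 sulfur; no ring) in place of a group of 10 heavy atoms (4 carbon, 2 nitrogen, 2 oxygen, 2 sulfur; no ring), on an aromatic carbon. Among the compounds with values here, no step between measured compounds that differ in one place is available here to anchor this change, so the expectation rests on compound 1 alone. Because compound 1 reaches 102%, the shared core with the much shorter group is expected to keep a large part of that effect, with a moderate decrease the likelier direction. Compound 3 is expected to show the step of a number 22 percentage points lower from compound 1 to compound 3 (beyond the scatter). Compound 3 is therefore estimated at 80%, within 45% to 105%.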

Compound 3, a percentage reported as inhibition, at one concentration (the size of the read-out at that concentration, not a potency): 97.9%
Estimate against measurement, compound 3: 17.9 percentage points below; the measured number falls inside the stated range.
By their numbers in this assay, from the lowest: compound 2; then compounds 3 and 1 (each within the scatter of the next).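

In this assay, the exchange on this aromatic carbon gives a number 4.1 percentage points lower from compound 1 to compound 3 (within the scatter), so the group of 10 heavy atoms and the group of 3 heavy atoms cannot be told apart by this reading. The longer group, with its hydrogen-bond donor, is therefore not needed at this position to hold the effect seen at the concentration tested, although a reading at one concentration is not a potency. No measurement shown here offers an explanation for this result.

The compounds shown leave open whether the group of 3 heavy atoms is itself needed, which an amine or a carboxylic acid on the same aromatic carbon would test. They also leave open whether compound 1 and compound 3 would still match at lower concentrations.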